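Dropping one chlorine from the dichlorophenyl amide

A few compounds are considered here, and "the series" means these few. Any claim that something is new, unique, unknown or untested is made for them only; others in the source may bear on it.

Of the compounds shown here, three sharing one core have been measured in a functional assay on HEK293 cells for agonist activity at D(4) dopamine receptor (Homo sapiens), read by FLIPR (on this read-out lower numbers stand for an effect already at smaller amounts and higher numbers for an effect only at larger amounts of compound), so far. Compound 1 `Cc1cc(NC(=O)CN2CCC(c3cccc[n+]3[O-])CC2)ccc1F` gives 18 nM, compound 2 `CC(C)Oc1cccc(NC(=O)CN2CCC(c3cccc[n+]3[O-])CC2)c1` gives 555 nM, and compound 3 `O=C(CN1CCC(c2cccc[n+]2[O-])CC1)Nc1cccc(Cl)c1Cl` gives 180 nM. Compound 3 therefore stands second highest of the three numbers: its nearest neighbour is compound 2, and its most distant is compound 1. The only single-point step recorded among these is a 10-fold higher number from compound 1 to compound 3 (1.00 log units; beyond the scatter).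

Compound 4 `O=C(CN1CCC(c2cccc[n+]2[O-])CC1)Nc1cccc(Cl)c1` differs from compound 3 in one place: hydrogen in place of chloro on an aromatic carbon. Among the measured compounds shown here, no measured pair isolates the removal of a single chloro group from this aromatic ring, so the step from compound 1 to compound 3 bears on it only loosely, as it shows that what sits on the amide-bound ring does move this assay. A small shift is expected in this assay, probably toward a lower number, since compound 1, which carries only small groups on that ring, gives 18 nM, while the substitution pattern of compound 4 is not directly represented. The estimated change is a 1.8-fold lower number from compound 3 to compound 4 (0.26 log units; within the scatter). For compound 4 the expected value is 100 nM, with a range from 30 nM to 350 nM.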

Compound 4, half-maximal effective concentration: 62 nM
For compound 4 the middle estimate is 1.6-fold (0.21 log units) above the measured one; measured number inside the range.
By their numbers in this assay, from the lowest: compound 1; then compound 4; then compound 3; then compound 2.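

In this assay, among the compounds shown here, the step from 2,3-dichlorophenyl to 3-chlorophenyl gives a 2.9-fold lower number from compound 3 to compound 4 (0.46 log units; beyond the scatter), the first measured pair to isolate this one position on the ring, and it shows that a chloro group on this carbon, ortho to a chloro group, costs more than the scatter can account for. Compound 4 also gives a reading of the other carbon: with chloro in place of isopropoxy on an aromatic carbon, the shift is a 9.0-fold lower number from compound 2 to compound 4 (0.95 log units; beyond the scatter), larger than the change from removing the chloro group. Even so, losing that chloro group does not close the whole distance to the lowest number of the set, since 3-chlorophenyl in place of 4-fluoro-3-methylphenyl on the amide-type nitrogen gives a 3.4-fold higher number from compound 1 to compound 4 (0.54 log units; beyond the scatter).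

Nothing available explains why these numbers move as they do. The compounds shown leave open whether a nitrile, a methoxy group or an amine on the carbon that now bears hydrogen would read closer to chloro or to hydrogen, and what happens when the remaining chloro group of compound 4 also gives way to hydrogen.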